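Dropping the Isobutoxy Group from Compound 1

This account rests on a few compounds, and the source may have more. Where it says the series, first, only, none or still open, it means among the compounds named here.

Compound 1 `CC(C)COc1cccc2occ(Cc3coc4ccccc4c3=O)c(=O)c12` was tested in a functional assay on NCI-H23 cells (Homo sapiens) for antiproliferative activity, read by XTT assay; a lower number here means a stronger inhibitor, a higher number a weaker inhibitor. In this assay compound 1 gives > 10000 nM, which is a limit of the assay rather than a measured number, as noted in the limit of > 10000 nM in this assay, at which 1 of the 3 values shown sits. Two related compounds gave numbers: compound 2 `COc1ccc2c(=O)c(Cc3coc4cccc(OCC5CCCCC5)c4c3=O)coc2c1` gives 1320 nM in this assay, and compound 3 `O=c1c(Cc2coc3cccc(OCC4CCCCC4)c3c2=O)coc2cc(O)ccc12` gives 2150 nM. For the measured compounds named here, the only step between measured compounds, a 1.6-fold higher number from compound 2 to compound 3 (0.21 log units; within the scatter), swaps a methyl for hydrogen on an oxygen and stays within the scatter. Compound 4 `O=c1c(Cc2coc3ccccc3c2=O)coc2ccccc12` differs from compound 1 by hydrogen in place of isobutoxy on an aromatic carbon. Going by the values given here, no measured step removes an alkoxy group from the core, so the one step available does not bear on this change directly. With compound 1 known only as a limit, the starting point itself is uncertain. Compound 4 is therefore expected to remain weak, with an estimate of 10000 nM and a range from 3000 nM to 30000 nM. This estimate amounts to the expected step of a number no higher from compound 1 to compound 4 (the limit leaves the size open).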

Compound 4, half-maximal inhibitory concentration: 1400 nM
Beside the measured number, compound 4's estimate is 7.1-fold (0.85 log units) above it, outside the stated range (below it).
By their numbers in this assay, from the lowest: compounds 2, 4 and 3 (each within the scatter of the next). At a limit, above all of these: compound 1.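

Removing the isobutoxy group from this aromatic carbon improves the result in this assay, giving an at least 7.1-fold lower number from compound 1 to compound 4 (0.85 log units; beyond the scatter). This is the first step shown at this position and the first to lie beyond the scatter, as the earlier step changed only a methyl on an oxygen elsewhere on the core and stayed within it. So compound 4 shows that the isobutoxy group is not needed for activity here, but the true size of the step remains unknown, and compound 1 gives only a limit: the limit of > 10000 nM in this assay, at which 1 of the 4 values shown sits.

On these data alone, whether a small group such as fluorine, an amine or a shorter alkoxy chain on this carbon would match hydrogen remains open. Compound 2 and compound 3 differ from compound 4 in more than one place, so they cannot show how their cyclohexylmethoxy group compares with hydrogen.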